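This account rests on a few compounds, and the source may have more. Where it says the series, first, only, none or still open, it means among the compounds named here.

Measured so far:
- compound 1, `CC(C)C1CN(c2ccccc2)NC(=O)N1`: 20000 nM
- compound 2, `O=C1NC(Oc2ccc(F)cc2)CN(c2ccccc2)N1`: 2600 nM
- compound 3, `Cc1cccc(N2CC(C)NC(=O)N2)n1`: 1700 nM

In a functional assay on cells for inhibition of Polyunsaturated fatty acid 5-lipoxygenase (Homo sapiens) (on this read-out lower numbers stand for stronger inhibition and higher numbers for weaker inhibition), compound 3 gives 1700 nM, the lowest of the three numbers. Compound 2, at 2600 nM, sits within the usual scatter of that number, so the two cannot be told apart. Compound 1, at 20000 nM, lies well beyond the scatter from compound 3, and its difference from compound 3 is the largest gap among the three.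

Compound 4, `CC1CN(c2cccc(F)n2)NC(=O)N1`, is not yet measured. It differs from compound 3 in one place: fluoro in place of methyl on an aromatic carbon. Among the measured compounds shown here, no pair of measured compounds shows this particular exchange, so there is no measured step to lean on; only the structures and the three values above can guide the estimate. The step expected for a 1.1-fold higher number from compound 3 to compound 4 (0.02 log units; within the scatter) is small and may not rise beyond the scatter in either direction. Compound 4 is therefore estimated at 1800 nM, with a range from 600 nM to 5500 nM.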

Compound 4, half-maximal inhibitory concentration: 6000 nM
For compound 4 the middle estimate is 3.3-fold (0.52 log units) below the measured one; the whole stated range lies below it.
By their numbers in this assay, from the lowest: compounds 3 and 2 (each within the scatter of the next); then compound 4; then compound 1.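

In this assay the aromatic carbon next to the ring nitrogen proves sensitive to which group it carries: fluoro in place of methyl gives a 3.5-fold higher number from compound 3 to compound 4 (0.55 log units; beyond the scatter) and so moves the number beyond the scatter. Among the compounds shown here, this is the first one-place comparison in the set, and it shows that the exchange matters even though both groups count a single heavy atom and neither adds a hydrogen-bond donor or acceptor. No measured evidence here bears on what lies behind this step.

From the compounds shown here alone, it remains open how a plain hydrogen, a chlorine, an ethyl or an amine at this position would compare with methyl and fluoro. Going by these compounds, it also remains open whether the same exchange would give a step of similar size on a different core, such as that of compound 1.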